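The source may hold more compounds than are shown below. What is called first, only, known or untested is meant among the compounds shown, and "the series" means these compounds.

The measured compounds:
Compound 1 `Cc1cc(C)cc(NC(=O)COc2cc(C)nc3ccc(OC(F)(F)F)cc23)c1` gives > 100000 nM in a toxicity assay on HepG2 cells (Homo sapiens) for inhibition, read by CellTiter-Glo, with a stated time of 48 h (a higher number here means a weaker inhibitor, a lower number a stronger inhibitor), a limit of the assay and not a number.
Compound 2 `COc1ccc2nc(C)cc(OCC(=O)NCc3cc(C)cc(C)c3)c2c1` gives > 100000 nM in this assay, again only a limit.
Compound 3 `COc1ccc2nc(C)cc(OCCNc3cc(C)cc(C)c3)c2c1` gives 31600 nM in this assay.

Compound 2 thus stands only at a limit, sharing it with compound 1 (the limit of > 100000 nM in this assay, at which 2 of the 3 values shown sit), while compound 3 alone returns a number. Compound 4 `COc1ccc(NC(=O)COc2cc(C)nc3ccc(OC)cc23)cc1` differs from compound 2 by 4-methoxyphenyl in place of 3,5-dimethylbenzyl on an amide-type nitrogen. Among the compounds with values here, no step between measured compounds is known, so no direction can be read from the data. Compound 4 is expected to remain at the limit, the step from compound 2 to compound 4 being estimated as a number no higher from compound 2 to compound 4 (the limit leaves the size open), none beyond the scatter. Compound 4 is estimated at 100000 nM in this assay, between 30000 nM and 300000 nM.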

Compound 4, half-maximal inhibitory concentration: > 100000 nM
Compound 4 ended at the assay's limit; the forecaster's own chance of this, stated with the estimate: 75%; the middle value lies on the limit itself.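

No new step can be read: compound 2 and compound 4 both stand only at a limit in this assay and not at a number. The compounds shown leave open whether 4-methoxyphenyl in place of 3,5-dimethylbenzyl on an amide-type nitrogen changes the value at all, and in which direction.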